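This account rests on a few compounds, and the source may have more. Where it says the series, first, only, none or still open, it means among the compounds named here.

Working notes on the series. The measured read-out throughout is a functional assay on the whole organism (Tail, strain ICR) with Mus musculus as the target, in the tail flick test, with a stated time of 60 min, at a dose of 25 umol/kg by the oral route; a higher number here means a stronger effect of the compound at the dose given, a lower number a weaker effect. Going by the values given here, compound 1 `N=C(N)NCCC[C@H](NC(=O)CN(c1ncnc2c1ncn2C1CCCCO1)C1CC1)C(=O)OCc1ccccc1` gives 52.4% and stands highest of the three numbers so far. Compound 3 `O=C(CN(c1nc(Cl)nc2[nH]cnc12)C1CC1)NCC(=O)OCc1ccccc1` gives 41.9%, and compound 2 `O=C(CN(c1nc(Cl)nc2[nH]cnc12)C1CC1)N[C@@H](CC(=O)OCc1ccccc1)C(=O)OCc1ccccc1` gives 22.4%; compounds 2 and 3 share a core that is not the core of compound 1. Among the compounds with values here, the one single-point step measured so far is a number 19.5 percentage points higher from compound 2 to compound 3 (beyond the scatter), which shows that the group on the chain carbon bound to the amide-type nitrogen and the carbonyl carbon can move this assay by a modest amount.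

Compound 4 `CSCC[C@H](NC(=O)CN(c1ncnc2c1ncn2C1CCCCO1)C1CC1)C(=O)OCc1ccccc1` keeps the core of compound 1 and differs from it by a group of 2 heavy atoms (1 carbon, 1 sulfur; no ring) in place of a group of 5 heavy atoms (2 carbon, 3 nitrogen; no ring), on a saturated chain carbon, three bonds along the chain from an amide-type nitrogen and a carbonyl carbon. Within the data shown here, no measured pair shows this exchange, and the step from compound 2 to compound 3 concerns a different group at a different place, so it serves only as a guide to the size of change that a side-chain exchange can bring. With the larger group of compound 1 removed, a modest loss beyond the scatter is expected, giving an estimated step of a number 14.4 percentage points lower from compound 1 to compound 4 (beyond the scatter). Compound 4 is therefore expected to give about 38%, with a range from 20% to 58%.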

Compound 4, a percentage reported as activity, at one dose (the size of the read-out at that dose, not a potency): 41%
Estimate against measurement, compound 4: 3 percentage points below; low and high end bracket the measured number.
By their numbers in this assay, from the lowest: compound 2; then compounds 4 and 3 (each within the scatter of the next); then compound 1.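

On the core of compound 1, the group on the saturated chain carbon, three bonds along the chain from an amide-type nitrogen and a carbonyl carbon, affects this assay: the exchange gives a number 11.4 percentage points lower from compound 1 to compound 4 (beyond the scatter). Going by these compounds alone, this is the first measured step at this position, as the earlier step concerned a different place on a different core, and it shows that the read-out does not vanish when a group counted with 3 hydrogen-bond donors gives way to methylsulfanyl, counted with 0, with compound 4 still at 41%. No measurement of a property of either group is available to account for this step.

The exchange changes the heavy-atom count, the donor count and the atom types together, so the compounds shown cannot assign the step to any one of these. Going by these compounds, what a primary amine, a carboxylic acid or a plain longer alkyl chain would give on the same chain carbon stays open, as does whether the step holds at other doses, since the read-out comes from a single dose and is not a potency.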